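The source may hold more compounds than are shown below. What is called first, only, known or untested is meant among the compounds shown, and "the series" means these compounds.

Compound 1 `CC1=CC[C@H](C(C)(C)NC(=S)NN)CC1` is the smallest of the three measured compounds; in a functional assay on U-251 cells (Homo sapiens) for inhibition, read by sulforhodamine B assay, with a stated time of 48 h (a lower number here means a stronger inhibitor of growth, a higher number a weaker inhibitor of growth), compound 1 gives 10100 nM. Compound 2 `CC1=CC[C@H](C(C)(C)NC(=S)N/N=C/c2ccc(O)cc2)CC1` carries a hydroxyphenyl group on the shared core. In this assay compound 2 reaches only a limit, > 100000 nM. Compound 3 `CC1=CC[C@H](C(C)(C)NC(=S)N/N=C/c2ccc(Cl)cc2)CC1` carries a chlorophenyl group instead. In this assay compound 3 likewise reaches only a limit, > 100000 nM. Thus a step that the two limits leave unreadable from compound 2 to compound 3, and compound 3 stands, together with compound 2, at the limit of > 100000 nM in this assay, at which 2 of the 3 values shown sit, while compound 1 alone gives a number. Compound 4 `CC1=CC[C@H](C(C)(C)NC(=S)N/N=C/c2cccs2)CC1` arises by thiophen-2-yl in place of 4-chlorophenyl on a carbon with a double bond to nitrogen. Within the data shown here, no measured step isolates this exchange, and the single measured step is unreadable. Compound 4 is therefore expected to stay weak, with an estimated step of an at least 1.2-fold lower number from compound 3 to compound 4 (0.09 log units; that floor lies within the scatter) and an estimated value of 80000 nM, between 20000 nM and 300000 nM.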

Compound 4, concentration for total growth inhibition: 27400 nM
For compound 4 the middle estimate is 2.9-fold (0.47 log units) above the measured one; measured number inside the range.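

On a carbon with a double bond to nitrogen, thiophen-2-yl gives a readable number in this assay, with an at least 3.6-fold lower number from compound 3 to compound 4 (0.56 log units; beyond the scatter) and an at least 3.6-fold lower number from compound 2 to compound 4 (0.56 log units; beyond the scatter). An aromatic ring at this place therefore does not always leave the compound at a limit, as compound 2 and compound 3 do: the limit of > 100000 nM in this assay, at which 2 of the 4 values shown sit. Even so, the added group leaves a weaker inhibitor of growth, with a 2.7-fold higher number from compound 1 to compound 4 (0.43 log units; beyond the scatter).

The compounds shown do not separate the part played by the ring sulfur from that of the smaller ring. They also leave open how a furan-2-yl or pyridin-2-yl group, or an amine on the thiophen-2-yl ring, would behave.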